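Anilide series: ethoxy homologue expected from the methoxy parent

The compounds below may be only part of what the source reports. "The series", "measured", "known", "first", "only" and "open" are said of these compounds alone.

Measured compounds and their values in a functional assay on HCT-8 cells (Homo sapiens) for antiproliferative activity, read by MTT assay, with a stated time of 48 h; a higher number here means a weaker inhibitor, a lower number a stronger inhibitor:
- compound 1 `CNCC(=O)Nc1cc(OC)ccc1C(=O)c1ccc(OC)c2c1C=CC(C)(C)O2`: 3460 nM
- compound 2 `CCNCC(=O)Nc1cc(OC)ccc1C(=O)c1ccc(OC)c2c1C=CC(C)(C)O2`: 7890 nM
- compound 3 `C=C(c1cc(OC)c(OC)c(OC)c1)c1ccc(OC)c(O)c1NC(=O)COC`: 280 nM

Compound 3 stands lowest of the three numbers in this assay; the gap to compound 1 and the wider gap to compound 2 both lie beyond the scatter. How the core of compound 3 differs from the core of compound 1 is not broken down here.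

Within the data shown here, the one measured single-point step is the change from compound 1 to compound 2, (methyl in place of hydrogen on a saturated chain carbon bound to an amine nitrogen), which gave a 2.3-fold higher number from compound 1 to compound 2 (0.36 log units; beyond the scatter), a modest weakening.

Compound 4 `C=C(c1cc(OC)c(OC)c(OC)c1)c1ccc(OC)c(O)c1NC(=O)COCC` is not yet measured. It arises from compound 3 by methyl in place of hydrogen on a saturated chain carbon bound to an oxygen on a saturated carbon. Among the measured compounds shown here, this is the same kind of change as the one from compound 1 to compound 2, not the same: there the methyl enters on a saturated chain carbon bound to an amine nitrogen, here on a saturated chain carbon bound to an oxygen on a saturated carbon, and the cores differ as well.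

Compound 4 is expected to show a 1.8-fold higher number from compound 3 to compound 4 (0.25 log units; within the scatter) in this assay, a step of about the same modest size and direction as the earlier one, resting on compound 1 to compound 2 giving a 2.3-fold higher number from compound 1 to compound 2 (0.36 log units; beyond the scatter) and on compound 3 giving 280 nM. The estimate for compound 4 in this assay is 500 nM, with a likely range from 230 nM to 1100 nM.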

Compound 4, half-maximal inhibitory concentration: 910 nM
The estimate for compound 4 lay 1.8-fold (0.26 log units) below the measured number, and the stated range covers the measured number.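

In this assay, methyl in place of hydrogen on a saturated chain carbon bound to an oxygen on a saturated carbon, the methoxymethyl to ethoxymethyl change on the anilide, gave a 3.3-fold higher number from compound 3 to compound 4 (0.51 log units; beyond the scatter), in the same direction as the earlier step on the other core. Set side by side, the two steps do not differ in size, so in these two pairs the added methyl carries from one core to the other as a modest weakening of about the same extent: the same change on two cores in this assay, a 2.3-fold higher number (0.36 log units; beyond the scatter) from compound 1 to compound 2 and a 3.3-fold higher number (0.51 log units; beyond the scatter) from compound 3 to compound 4, 1.4-fold (0.15 log units) apart, within the scatter of two such steps. Among these compounds, this rests on only two pairs, and the methyl sits on a chain carbon bound to an amine nitrogen in one pair and to an oxygen in the other, so the agreement shows neither that the step holds on further cores nor how far the core and the neighbouring atom each contribute to it.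

Still open, going by these compounds, is whether a longer chain on the ether oxygen, such as propoxy, would continue the same trend on the core of compound 3. Also open, on these data alone, is how an amine in place of that ether oxygen would read on this core, and an ether chain on the core of compound 1.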